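Methoxy positional isomer of compound 1: lipophilicity notes

A few compounds are considered here, and "the series" means these few. Any claim that something is new, unique, unknown or untested is made for them only; others in the source may bear on it.

Within the data shown here, compound 1 `COc1cccc(CNCc2c(-c3nnc(SC(C)C)n3-c3ccccc3)n(C)c3ccccc23)c1` gives 6.27 in a physicochemical assay for lipophilicity (a higher number here means a more lipophilic compound, a lower number a more polar compound), the second highest of the three numbers measured so far. Compound 2 `COc1ccc(CNCc2c(-c3nnc(SC(C)C)n3-c3ccccc3)n(C)c3ccc(F)cc23)cc1` gives 6.42, within the scatter of compound 1. Among the measured compounds shown here, compound 3 `CC1CCN(Cc2c(-c3nnc(SC(C)C)n3-c3ccccc3)n(C)c3ccccc23)CC1` gives 5.96; the step of a number 0.31 log units lower from compound 1 to compound 3 (beyond the scatter) is the only measured step that starts from compound 1, and it exchanges the whole amine substituent rather than a ring position. Compound 4 `COc1ccc(CNCc2c(-c3nnc(SC(C)C)n3-c3ccccc3)n(C)c3ccccc23)cc1` differs from compound 1 by 4-methoxyphenyl in place of 3-methoxyphenyl on a saturated chain carbon bound to an amine nitrogen. For the measured compounds named here, no measured step moves a methoxy group around its ring; with the same atoms joined differently, the step expected in this assay is none beyond the scatter. Compound 4 is therefore estimated at 6.25, between 5.9 and 6.6, an expected step of a number 0.02 log units lower from compound 1 to compound 4 (within the scatter).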

Compound 4, partition coefficient: 6.27
Compound 4: middle estimate off by 0.02 log units, on the low side, within the range that was stated.
By their numbers in this assay, from the lowest: compound 3; then compounds 1, 4 and 2 (each within the scatter of the next).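

Moving the methoxy group from 3-methoxyphenyl to 4-methoxyphenyl on a saturated chain carbon bound to an amine nitrogen gives in this assay no change at the digits printed from compound 1 to compound 4 (within the scatter) so ring position is now read directly at this place and does not separate the two isomers. Exchanging the whole amine substituent still registers, with a number 0.31 log units higher from compound 3 to compound 4 (beyond the scatter) for the new isomer, while a number 0.15 log units lower from compound 2 to compound 4 (within the scatter) shows that the fluoro group is not resolved here either. No evidence on the cause of these numbers is available.

On these data alone, whether a hydroxyl in place of the methoxy group, or a carboxylic acid on the same ring, would move the number stays open.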